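The compounds below may be only part of what the source reports. "The series", "measured", "known", "first", "only" and "open" are said of these compounds alone.

Measured compounds:
compound 1 `CNC(=O)c1cc(C(=O)N[C@H]2CC[C@H](O)CC2)n([C@@H](C)c2ccccc2)n1`: 80 nm/s
compound 2 `CNC(=O)c1cc(C(=O)N[C@H]2CC[C@H](OC)CC2)c([C@@H](C)c2ccccc2)o1`: 303 nm/s
compound 3 `CNC(=O)c1cc(C(=O)NC2CC2)n(Cc2ccccc2)n1`: > 80 nm/s, a limit

In an ADME assay for permeability (on this read-out higher numbers stand for higher permeability and lower numbers for lower permeability), compound 2 gives 303 nm/s, the highest of the two numbers shown; compound 1 gives 80 nm/s, and the gap between them lies beyond the scatter. For compound 3 the value > 80 nm/s is a limit of this assay rather than a number (the limit of > 80 nm/s in this assay, at which 1 of the 3 values shown sits). Compound 4 `CNC(=O)c1cc(C(=O)N[C@H]2CC[C@H](O)CC2)c([C@@H](C)c2ccccc2)o1` differs from compound 2 in one place: hydrogen in place of methyl on an oxygen on a saturated carbon. Among the measured compounds shown here, no measured pair isolates this change. Compound 1, which carries hydroxy rather than methoxy at that place on a different core, gives 80 nm/s and lies well under compound 2. A decrease beyond the scatter is therefore expected, a 2.5-fold lower number from compound 2 to compound 4 (0.40 log units; beyond the scatter). Compound 4 is estimated at 120 nm/s, in a range from 50 nm/s to 260 nm/s.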

Compound 4, apparent permeability: 42 nm/s
Beside the measured number, compound 4's estimate is 2.9-fold (0.46 log units) above it; the whole stated range lies above it.
By their numbers in this assay, from the lowest: compounds 4 and 1 (each within the scatter of the next); then compound 2.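

In this assay, the change from 4-methoxycyclohexyl to 4-hydroxycyclohexyl now has a measured pair on one core, and it gives a 7.2-fold lower number from compound 2 to compound 4 (0.86 log units; beyond the scatter) as its step. On this core, the methyl on the oxygen is the only difference, so this position clearly affects the read-out. No data shown bear on the cause of this step.

As far as these compounds go, whether the step holds on the core of compound 1 remains open. So does the effect of an amine or an ethoxy group at this place.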